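Triazole lactone series: dropping the aryl group

The source may report more compounds than this note shows. Statements on the series, on what has been measured and on what is new or still open speak of the compounds shown alone.

Values in a functional assay on MCF7 cells (Homo sapiens) for antiproliferative activity, read by MTT assay, with a stated time of 72 h; a lower number here means a stronger inhibitor, a higher number a weaker inhibitor:
compound 1 `COc1ccc(-c2cn(C[C@H](O)[C@H]3OC(=O)C(OCc4ccccc4)=C3OCc3ccccc3)nn2)cc1`: 99700 nM
compound 2 `Cc1ccc(-c2cn(C[C@H](O)[C@H]3OC(=O)C(OCc4ccccc4)=C3OCc3ccccc3)nn2)cc1`: > 100000 nM

Compound 2 sits at the weak end, and its value in this assay is a limit, not a number (the limit of > 100000 nM in this assay, at which 1 of the 2 values shown sits). Compound 3 `O=C1O[C@H]([C@@H](O)Cn2ccnn2)C(OCc2ccccc2)=C1OCc1ccccc1` differs from compound 2 by hydrogen in place of 4-methylphenyl on an aromatic carbon. Within the data shown here, the only measured step, a number no lower from compound 1 to compound 2 (the limit leaves the size open), touches a different part of the molecule and its size is not readable, so it gives no direction here. Both measured compounds being weak, compound 3 is expected to stay weak, with an expected step of a number no higher from compound 2 to compound 3 (the limit leaves the size open) of no clear size. Compound 3 is estimated at 100000 nM, between 40000 nM and 250000 nM.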

Compound 3, half-maximal inhibitory concentration: > 100000 nM
Compound 3: a limit, no number; the forecaster's own chance of this, stated with the estimate: 60%; the middle value sits exactly at the limit.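

Compound 3, with hydrogen on this aromatic carbon, gives > 100000 nM in this assay, which is a limit and not a number. Hydrogen in place of 4-methoxyphenyl gives a number no lower from compound 1 to compound 3 (the limit leaves the size open), so dropping the aryl group altogether brings no readable gain in this assay. The step between the two methyl and hydrogen compounds cannot be read, because both values are limits: the limit of > 100000 nM in this assay, at which 2 of the 3 values shown sit.

On these data alone, whether an amine or a carboxylic acid on this aromatic carbon would give a value clear of that limit stays open.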